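The compounds below may be only part of what the source reports. "The series", "measured", "known", "first", "only" and "open" are said of these compounds alone.

Of the compounds shown here, two built on a shared core have been measured in a functional assay on WI-38 VA13 cells (Homo sapiens) for cytotoxicity; on this read-out lower numbers stand for an effect already at smaller amounts and higher numbers for an effect only at larger amounts of compound. Compound 1 `COc1ccc(C(=O)Nc2ccc3nc(NC(=O)C4CCCCC4)sc3c2)cc1` gives 4.9 ug/mL in this assay. Compound 2 `NCCC(=O)Nc1nc2ccc(NC(=O)c3c(Cl)cccc3Cl)cc2s1` gives 5.3 ug/mL in this assay; its number sits alongside that of compound 1, the two lying within the usual scatter of repeated measurements, so no order between them can be read. Compound 3 `COc1cccc(Nc2nc3ccc(NC(=O)c4c(Cl)cccc4Cl)cc3s2)c1` has not yet been measured. It differs from compound 2 in one place: 3-methoxyphenyl in place of (2-aminoethyl)carbonyl on a nitrogen on an aromatic ring. A group with no ring gives way to one six-membered aromatic ring of carbon only. For the measured compounds named here, with only two measured compounds and no step between them to lean on, the data give no sign of how such a change moves the read-out. The step expected here, no change at the digits printed from compound 2 to compound 3 (within the scatter), is none beyond the scatter. Compound 3 is therefore estimated at 5.3 ug/mL in this assay, with a range from 1.8 ug/mL to 16 ug/mL.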

Compound 3, half-maximal effective concentration: > 7.2 ug/mL
Compound 3: no number, only a limit; the forecaster's own chance of this, stated with the estimate: 5%; at least 1.3-fold (0.13 log units) between middle value and limit.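

Putting 3-methoxyphenyl in place of (2-aminoethyl)carbonyl on this nitrogen gives the first step seen at this position: an at least 1.3-fold higher number from compound 2 to compound 3 (0.13 log units; that floor lies within the scatter). So a six-membered aromatic ring without the amine-bearing chain can sit here without bringing the number down, although a step this small at its floor cannot be told apart from repeat-to-repeat variation. How far the true number of compound 3 lies past that floor cannot be told because the reading stops at a limit: the limit of > 7.2 ug/mL in this assay, at which 1 of the 3 values shown sits.

Going by these compounds, whether the ring itself or its methoxy group matters stays open, as a plain phenyl ring would be needed to separate the two. On these data alone, how a longer chain ending in an amine or a carboxylic acid would read on this nitrogen also stays open.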